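Aryl swap on the shared core: liver microsome stability

The compounds below may be only part of what the source reports. "The series", "measured", "known", "first", "only" and "open" are said of these compounds alone.

Compound 1 `Nc1nc(NCCNc2ncc(-c3ncc[nH]3)c(-c3cc(F)ccc3F)n2)ccc1[N+](=O)[O-]` is the reference point of the series. In an ADME assay on microsomes from liver (Canis lupus familiaris) for metabolic stability (on this read-out lower numbers stand for a shorter-lived compound and higher numbers for a longer-lived compound), compound 1 gives > 0.5 h, which is a limit of the assay and not a number. Compound 2 `Nc1nc(NCCNc2ncc(-c3ncc[nH]3)c(-c3cc(F)c(Cl)cc3Cl)n2)ccc1[N+](=O)[O-]` gives > 0.5 h in this assay, again a limit. Within the data shown here, the one measured step, a step that the two limits leave unreadable from compound 1 to compound 2, therefore cannot be sized; the limit of > 0.5 h in this assay, at which 2 of the 2 values shown sit, summarises the standing. Compound 3 `COc1cc(Cl)ccc1-c1nc(NCCNc2ccc([N+](=O)[O-])c(N)n2)ncc1-c1ncc[nH]1` carries the change (4-chloro-2-methoxyphenyl in place of 2,5-difluorophenyl on an aromatic carbon). Among the measured compounds shown here, no measured step bears readably on it, so no direction is expected beyond the scatter. Compound 3 is expected to give 1 h, within 0.4 h to 3 h. The expected step is a step that the limit leaves unreadable from compound 1 to compound 3.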

Compound 3, half-life: > 0.5 h
Compound 3: only a limit was reported (the forecaster's own chance of this, stated with the estimate: 75%); the middle value lies beyond the limit too.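

The steps from compound 1 and compound 2 to compound 3 cannot be read, and the standing in this assay remains a single limit: the limit of > 0.5 h in this assay, at which 3 of the 3 values shown sit.

As far as these compounds go, how far each compound lies beyond that limit, and so how the three aryl groups compare, stays open.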